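Trifluoromethyl in place of trifluoromethoxy on compound 1

The compounds below may be only part of what the source reports. "The series", "measured", "known", "first", "only" and "open" are said of these compounds alone.

Compound 1 `Cc1cc(NC(=O)Nc2ccccc2OC(F)(F)F)c2ccccc2n1` gives > 25000 nM (a limit)
Compound 2 `Cc1cc(NC(=O)Nc2cc(F)cc(F)c2)c2ccccc2n1` gives > 25000 nM (a limit)

In an ADME assay on HEK293 cells (Homo sapiens) for cytotoxicity, with a stated time of 72 h (on this read-out lower numbers stand for an effect already at smaller amounts and higher numbers for an effect only at larger amounts of compound), compound 1 stands at the limit of > 25000 nM in this assay, at which 2 of the 2 values shown sit, and has no exact number. Compound 3 `Cc1cc(NC(=O)Nc2ccccc2C(F)(F)F)c2ccccc2n1` has not been measured, and it carries trifluoromethyl in place of trifluoromethoxy on an aromatic carbon, ortho to a large group (trifluoromethyl in place of trifluoromethoxy on an aromatic carbon) with the rest unchanged. For the measured compounds named here, no measured pair shows this swap. With compound 1 at > 25000 nM as a limit, no change beyond the scatter is expected in this assay from this swap. The expected size is a number no higher from compound 1 to compound 3 (the limit leaves the size open) and no more than the scatter. Compound 3 is estimated at 25000 nM with a range of 15000 nM to 50000 nM and may well return only a limit.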

Compound 3, half-maximal effective concentration: > 25000 nM
Compound 3: no number, only a limit; the forecaster's own chance of this, stated with the estimate: 85%; the middle value sits exactly at the limit.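

Compound 1 and compound 3 both return only a limit in this assay, so no step between them can be read: the limit of > 25000 nM in this assay, at which 3 of the 3 values shown sit.

The compounds shown leave open whether trifluoromethyl in place of trifluoromethoxy changes this read-out at all.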